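Isopropyl carboxamide analogue of the thienyl dihydropyrimidinone series

A few compounds are considered here, and "the series" means these few. Any claim that something is new, unique, unknown or untested is made for them only; others in the source may bear on it.

Measured so far:
compound 1 `CCCOC(=O)C1=C(C)N(C)C(=O)NC1c1ccsc1` — 1%
compound 2 `CC1=C(C(=O)OCC(C)C)C(c2ccsc2)NC(=O)N1C` — 1%
compound 3 `CCNC(=O)C1=C(C)NC(=O)NC1c1cccs1` — 1%

In an assay on membranes from HEK293 cells for displacement of a labelled ligand from adenosine receptor A2b (Homo sapiens), read by scintillation counting, with a stated time of 30 min, tested at 1 uM (a lower number here means less inhibition, a higher number more inhibition at the concentration tested (going by the name of the read-out)), compound 1 gives 1% and compound 2 gives 1%. The step of no change at the digits printed from compound 1 to compound 2 (within the scatter) belongs to methyl in place of hydrogen on a saturated chain carbon bound to two saturated chain carbons. Compound 3 gives 1% in this assay; the difference between the core of compound 3 and the core of compound 1 is not broken down here, and the three values lie level.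

Compound 4 `CC1=C(C(=O)NC(C)C)C(c2cccs2)NC(=O)N1` arises from compound 3 by methyl in place of hydrogen on a saturated chain carbon bound to an amide-type nitrogen and a saturated chain carbon. This is the same kind of change as that from compound 1 to compound 2, not the same: there the carbon is bound to two saturated chain carbons, here to an amide-type nitrogen and a saturated chain carbon. A step of a number 1 percentage points higher from compound 3 to compound 4 (within the scatter) is expected, resting on compound 3 giving 1% and on the earlier step staying within the scatter. Compound 4 is expected to give 2%, between 0% and 10%.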

Compound 4, a percentage reported as inhibition, at one concentration (the size of the read-out at that concentration, not a potency): 40%
Beside the measured number, compound 4's estimate is 38 percentage points below it; the measured number lies above the stated range.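

The methyl change does not carry over unchanged between these cores in this assay: the same change on two cores in this assay, no change at the digits printed (within the scatter) from compound 1 to compound 2 and a number 39 percentage points higher (beyond the scatter) from compound 3 to compound 4, 39 percentage points apart, beyond the scatter of two such steps

On the core of compound 3, ethylcarbamoyl to isopropylcarbamoyl gives a number 39 percentage points higher from compound 3 to compound 4 (beyond the scatter), so the gain holds for this one pair and cannot be assumed for another core. The two methyl groups also sit on carbons with different neighbours, and the data do not separate that difference in place from the differences between the cores.

Going by these compounds, it remains open whether isopropylcarbamoyl would give a similar result on the core of compound 1. Also open, on these data alone, is how a longer chain or a cyclopropyl group on the amide nitrogen would read in this assay.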